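The source may hold more compounds than are shown below. What is called first, only, known or untested is meant among the compounds shown, and "the series" means these compounds.

Compound 1 `Cc1ccc(/C=C2\CCC/C(=C\c3ccccc3[N+](=O)[O-])C2=O)cc1` is one of three bis-benzylidene and benzylidene cyclic ketones examined in a functional assay on L1210 cells (Mus musculus) for cytotoxicity, with a stated time of 48 h; on this read-out higher numbers stand for weaker inhibition and lower numbers for stronger inhibition. In this assay compound 1 gives 7770 nM, the lowest of the three numbers. Compound 3 `Cc1ccc(/C=C2\CCC/C(=C\c3ccc([N+](=O)[O-])cc3)C2=O)cc1`, which carries its nitro group at a different position of the same kind of ring, gives 8160 nM, a number that sits within the scatter of that of compound 1, so no order between the two can be claimed. Compound 2 `O=C1CCCC/C1=C\c1cccc([N+](=O)[O-])c1`, which carries only a single nitrophenyl arm on its ketone, gives 50100 nM, and its distance from compound 1 is beyond the scatter.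

Compound 4 `O=C1/C(=C/c2ccccc2)CCC/C1=C\c1ccccc1[N+](=O)[O-]` has not yet been measured. It differs from compound 1 by a single change: hydrogen in place of methyl on an aromatic carbon, on an aromatic carbon of a six-membered aromatic ring of carbon only, para to a large group. Read one bond further out, the change is 4-methylphenyl to phenyl. Among the measured compounds shown here, no measured pair in this set shows the effect of removing such a methyl group, so there is no step to lean on. For a change this small on an arm remote from the nitro-bearing ring, the expected step from compound 1 to compound 4 in this assay is a 1.0-fold higher number from compound 1 to compound 4 (0.01 log units; within the scatter), with no direction anticipated beyond the scatter. Compound 4 is therefore estimated at 8000 nM, within a range of 4000 nM to 16000 nM.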

Compound 4, half-maximal inhibitory concentration: 4840 nM
Estimate against measurement, compound 4: 1.7-fold (0.22 log units) above; measured number inside the range.
By their numbers in this assay, from the lowest: compounds 4, 1 and 3 (each within the scatter of the next); then compound 2.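

Among the compounds shown here, this is the first direct reading of the place para to a large group on this aromatic ring. In this assay, going from 4-methylphenyl to phenyl gives a 1.6-fold lower number from compound 1 to compound 4 (0.21 log units; within the scatter), so the methyl group is not required for the level of cytotoxicity seen with compound 1, and hydrogen serves equally well there within the scatter. No supporting evidence bears on this result, so the data give no explanation for it.

The compounds shown leave open whether an amine, a carboxylic acid or a longer chain at this same place would shift the number beyond the scatter. They also leave open whether the same replacement would give a similar result on compound 3, which has its nitro group at a different position.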